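From Benzyl to Propyl on the Ring Amine Nitrogen

The source may report more compounds than this note shows. Statements on the series, on what has been measured and on what is new or still open speak of the compounds shown alone.

Compound 1 `COc1cc(N)c(Cl)cc1NC(=O)C1CCN(Cc2ccc(Cl)cc2)CC1`: 1.2 mg/kg
Compound 2 `COc1cc(N)c(Cl)cc1NC(=O)C1CCN(CC2CCCC2)CC1`: > 10 mg/kg
Compound 3 `COc1cc(N)c(Cl)cc1NC(=O)C1CCN(Cc2ccccc2)CC1`: 0.5 mg/kg

In a functional assay on the whole organism for antagonist activity, with Mus musculus as the target (a lower number here means that less compound is needed, a higher number that more compound is needed for the effect), compound 3 stands lowest of the two numbers given; compound 1 is nearest, with a 2.4-fold lower number from compound 1 to compound 3 (0.38 log units; beyond the scatter). For compound 2 the value is a limit of the assay (the limit of > 10 mg/kg in this assay, at which 1 of the 3 values shown sits). Compound 4 `CCCN1CCC(C(=O)Nc2cc(Cl)c(N)cc2OC)CC1` is compound 3 with ethyl in place of phenyl on a saturated chain carbon bound to an amine nitrogen in a ring. The step that bears most directly on this change is an at least 20-fold lower number from compound 2 to compound 3 (1.30 log units; beyond the scatter), where phenyl in place of cyclopentyl gave a large fall; an at least 8.3-fold higher number from compound 1 to compound 2 (0.92 log units; beyond the scatter) points the same way. Ethyl, with no ring, is therefore expected to raise the number by a large step, possibly up to the limit. The step expected is a 20-fold higher number from compound 3 to compound 4 (1.30 log units; beyond the scatter). Compound 4 is estimated at 10 mg/kg, within 3 mg/kg to 30 mg/kg.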

Compound 4, dose for half-maximal effect: > 10 mg/kg
Compound 4 was reported as a limit; the forecaster's own chance of this, stated with the estimate: 50%; the middle value sits exactly at the limit.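

In this assay, giving up the aromatic ring at this place for an open chain has a large cost, with an at least 20-fold higher number from compound 3 to compound 4 (1.30 log units; beyond the scatter), and the comparison with the chlorinated benzyl gives an at least 8.3-fold higher number from compound 1 to compound 4 (0.92 log units; beyond the scatter). Among the four compounds, only the two with an aromatic ring here, compound 1 and compound 3, give a reading below the limit, whether the ring is replaced by cyclopentyl or by ethyl. Compound 2 and compound 4 both sit at a limit, so the step between them cannot be read: the limit of > 10 mg/kg in this assay, at which 2 of the 4 values shown sit.

Still open, on these data alone, is whether a pyridine ring in place of phenyl would keep the low number. Also open, as far as these compounds go, is whether a longer chain ending in phenyl would do so.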